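Shortening an Ether Side Chain: Compound 2 to Compound 3

The compounds below may be only part of what the source reports. "The series", "measured", "known", "first", "only" and "open" are said of these compounds alone.

Compound 1 `Oc1cc(Cc2cc(O)c(O)c(Br)c2Br)c(Br)c(Br)c1O` and compound 2 `CCOCc1cc(O)c(O)c(Br)c1Cc1cc(O)c(O)c(Br)c1Br` share the same core and differ only in one side chain. In a functional assay on Bel-7402 cells (Homo sapiens) for cytotoxicity, read by MTT assay, with a stated time of 96 h (on this read-out higher numbers stand for weaker inhibition and lower numbers for stronger inhibition), compound 1 gives only a limit of the assay, > 18200 nM, so no number is known for it; this is the limit of > 18200 nM in this assay, at which 1 of the 2 values shown sits. Compound 2 gives 5500 nM in this assay and so stands as the only number shown.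

Compound 3 `COCc1cc(O)c(O)c(Br)c1Cc1cc(O)c(O)c(Br)c1Br` differs from compound 2 by hydrogen in place of methyl on a saturated chain carbon bound to an oxygen on a saturated carbon. Within the data shown here, no step between two measured compounds is available, so the size of this change can be judged only from the structures. The change is small, and the step from compound 2 to compound 3 in this assay is expected to stay within the usual scatter, with no clear direction. Compound 3 is therefore estimated at 5500 nM, in a range from 2500 nM to 13000 nM. The expected step is no change at the digits printed from compound 2 to compound 3 (within the scatter).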

Compound 3, half-maximal inhibitory concentration: 7400 nM
Compound 3: middle estimate off by 1.3-fold (0.13 log units), on the low side, and the stated range covers the measured number.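

In this assay this side chain now has its first step that can be read: a 1.3-fold higher number from compound 2 to compound 3 (0.13 log units; within the scatter). Going from ethoxymethyl to methoxymethyl removes a single methyl, and the read-out stays within the usual scatter, so in this one pair the end of the ether chain can be shortened without a clear change. No measured property shown here bears on this step.

For compound 1 the value is a limit of the assay, > 18200 nM, and not a number. From the compounds shown here alone, whether an amine, a carboxylic acid or a longer chain such as propoxymethyl in this place would stay within the scatter of these two compounds or move the read-out clearly remains open.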